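This account rests on a few compounds, and the source may have more. Where it says the series, first, only, none or still open, it means among the compounds named here.

Measured so far:
- compound 1, `O=c1[nH]c2ccccc2cc1/C=N/Cc1ccccc1`: 329000 nM
- compound 2, `O=c1[nH]c2ccccc2cc1/C=N/c1ccc(O)cc1`: 306000 nM
- compound 3, `Cc1ccc2[nH]c(=O)c(/C=N/Nc3ccccc3)cc2c1`: 309000 nM

All three were tested in a functional assay, read by spectrophotometry, with a stated time of 5 min; a higher number here means a weaker inhibitor, a lower number a stronger inhibitor. Compound 2 gives the lowest of the three numbers, yet its gaps to compound 3 and to compound 1 are both within the usual scatter of this assay, so the three cannot be told apart on these data. Across them, the shared core stays the same while the group hanging off the imine changes, and the numbers hardly move.

Compound 4, `NS(=O)(=O)c1ccc(/N=C/c2cc3ccccc3[nH]c2=O)cc1`, has not yet been measured. It is built from compound 2 by one change: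

sulfamoyl in place of hydroxy on an aromatic carbon

Going by the values given here, no step between two measured compounds has been quantified, so there is no measured reference for what such a swap does. What the data do show is that three rather different substituents give the same weak inhibition in this assay. On that basis the step from compound 2 to compound 4 is expected to be small, with no clear direction, and most likely to stay within the scatter: a 1.0-fold lower number from compound 2 to compound 4 (0.01 log units; within the scatter). The estimate for compound 4 in this assay is therefore 300000 nM, with a range from 100000 nM to 900000 nM.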

Compound 4, half-maximal inhibitory concentration: 169000 nM
For compound 4 the middle estimate is 1.8-fold (0.25 log units) above the measured one; low and high end bracket the measured number.
By their numbers in this assay, from the lowest: compounds 4, 2, 3 and 1 (each within the scatter of the next).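

In this assay, putting sulfamoyl in place of hydroxy on this aromatic carbon, para to a large group, gives a 1.8-fold lower number from compound 2 to compound 4 (0.26 log units; within the scatter). Going by these compounds alone, this is the first step between two compounds that differ in only one place, so the effect of a single swap can now be read directly rather than inferred from compounds that differ in several ways. It shows that, at this position, a hydroxy group can give way to the much larger sulfamoyl group, with its two double bonds outside aromatic rings, and the result still stays within the scatter, while no information is available on why the number behaves this way.

Still open, from the compounds shown here alone, is whether a different group on the same aromatic carbon, such as an amine, a carboxylic acid or a longer alkyl chain, would move the number beyond the scatter in either direction. Going by these compounds, it is also open whether sulfamoyl would give a similar step on a core carrying a methyl group, like the core of compound 3.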